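Adding a Methoxy to a Weakly Active Lactam

The source may hold more compounds than are shown below. What is called first, only, known or untested is meant among the compounds shown, and "the series" means these compounds.

Compound 1 `COc1ccc(/C=C/C2CC=CC(=O)O2)c(OC)c1` serves as the starting point of this account. In a functional assay on 786-0 cells (Homo sapiens) for inhibition, read by sulforhodamine B assay, with a stated time of 48 h (a lower number here means a stronger inhibitor of growth, a higher number a weaker inhibitor of growth), compound 1 gives 4.1 uM. Compound 2 `COc1cc(OC)c(OC)cc1/C=C/C1CC=CC(=O)O1` carries one further group, (methoxy in place of hydrogen on an aromatic carbon), and in this assay compound 2 gives 6 uM. The resulting step, a 1.5-fold higher number from compound 1 to compound 2 (0.17 log units; within the scatter), is small and lies within the scatter, so the two measured compounds of this core cannot be ranked against each other.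

Compound 3 `COc1ccc(/C=C/C2CC=CC(=O)N2)cc1` has a different core; the difference between the two cores is not broken down here. In this assay compound 3 gives only a limit, > 1090 uM, and no number. That compound sits at the limit of > 1090 uM in this assay, at which 1 of the 3 values shown sits.

Compound 4 `COc1ccc(/C=C/C2CC=CC(=O)N2)cc1OC` has not yet been measured. It differs from compound 3 by methoxy in place of hydrogen on an aromatic carbon. Among the measured compounds shown here, this is the same kind of change as the one from compound 1 to compound 2, though not the same: around the place in compound 2 there is also a methoxy group para to it, which the place in compound 4 lacks.

For the measured compounds named here, the only measured step of this kind, a 1.5-fold higher number from compound 1 to compound 2 (0.17 log units; within the scatter), is small. A step of about the same size is expected here, so the estimate is an at least 1.2-fold lower number from compound 3 to compound 4 (0.08 log units; that floor lies within the scatter). For compound 4 in this assay the expected value is 900 uM, between 150 uM and 3000 uM, with a substantial chance that only a limit is again reported.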

Compound 4, concentration for growth inhibition (reported as GI): > 964 uM
Compound 4 ended at the assay's limit; the forecaster's own chance of this, stated with the estimate: 65%; middle value at least 1.0-fold (0.02 log units) from the limit.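

Compound 4 gives only a limit in this assay, > 964 uM, and no number. Compound 3 also gives only a limit, > 1090 uM. With a limit on each side, the step from compound 3 to compound 4 cannot be read. The compounds shown leave open whether the added methoxy on the core of compound 3 changes growth inhibition at all.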